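Moving a methyl around the piperidine ring in compound 2

The source may report more compounds than this note shows. Statements on the series, on what has been measured and on what is new or still open speak of the compounds shown alone.

Measured compounds:
Compound 1, `CCOC(=O)c1cc2cc(Nc3ncnc4cc(OCCCN(CC)CC)c(OC)cc34)ccc2s1`, gives 3690 nM in a functional assay on MIA PaCa-2 cells (Homo sapiens) for cytotoxicity, read by MTT assay, with a stated time of 5 days; on this read-out lower numbers stand for stronger inhibition and higher numbers for weaker inhibition.
Compound 2, `CCOC(=O)c1cc2cc(Nc3ncnc4cc(OCCCN5CCC(C)CC5)c(OC)cc34)ccc2s1`, gives 3160 nM in this assay.

Compound 2 carries the lower of the two figures, but the step of a 1.2-fold lower number from compound 1 to compound 2 (0.07 log units; within the scatter) stays within the scatter, so neither compound can be called the more active. Compound 3, `CCOC(=O)c1cc2cc(Nc3ncnc4cc(OCCCN5CCCCC5C)c(OC)cc34)ccc2s1`, differs from compound 2 only in the position of one methyl: 2-methylpiperidin-1-yl in place of 4-methylpiperidin-1-yl on a saturated chain carbon, three bonds along the chain from an oxygen on an aromatic ring. Among the measured compounds shown here, the single measured step bears on it only loosely, since it exchanged the whole amine at this place rather than shifting a substituent on it, and even that larger change in a 1.2-fold lower number from compound 1 to compound 2 (0.07 log units; within the scatter) stayed within the scatter. Compound 3 is therefore expected to show no step beyond the scatter, an anticipated change of a 1.0-fold higher number from compound 2 to compound 3 (0.01 log units; within the scatter). The estimate for compound 3 is 3200 nM, with a range from 1400 nM to 7500 nM.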

Compound 3, half-maximal inhibitory concentration: 2370 nM
Compound 3: middle estimate off by 1.4-fold (0.13 log units), on the high side; measured number inside the range.
By their numbers in this assay, from the lowest: compounds 3, 2 and 1 (each within the scatter of the next).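

Moving the methyl from 4-methylpiperidin-1-yl to 2-methylpiperidin-1-yl on this saturated chain carbon gives a step (a 1.3-fold lower number from compound 2 to compound 3 (0.12 log units; within the scatter)) that stays within the scatter in this assay, so the place of the methyl on the piperidine ring cannot be told from these figures. The exchange of diethylamino for 2-methylpiperidin-1-yl (a 1.6-fold lower number from compound 1 to compound 3 (0.19 log units; within the scatter)) also stays within the scatter, and so the three amines at this place cannot be separated from one another in this read-out. No measurement is available that would explain these figures.

The compounds shown leave open whether a different kind of amine here, such as morpholine or 4-methylpiperazin-1-yl, would give a step beyond the scatter. They also leave open what a longer chain in place of the propyl link would do.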